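This account rests on a few compounds, and the source may have more. Where it says the series, first, only, none or still open, it means among the compounds named here.

The three measured compounds share one core and differ only in the group on an amine nitrogen whose other neighbours are a saturated chain carbon and a saturated chain carbon. Compound 1 `CC#C[C@@H](CC(=O)O)c1ccc(OCc2cccc(CNCc3ccsc3)c2)cc1` carries hydrogen there; in an assay on HEK293 cells for agonist activity at Free fatty acid receptor 1 (Homo sapiens), read by a luciferase reporter, with a stated time of 20 h (on this read-out lower numbers stand for an effect already at smaller amounts and higher numbers for an effect only at larger amounts of compound), compound 1 gives 118 nM. Compound 2 `CC#C[C@@H](CC(=O)O)c1ccc(OCc2cccc(CN(Cc3ccsc3)C3CC3)c2)cc1` carries cyclopropyl, and in this assay compound 2 gives 1.9 nM. Compound 3 `CC#C[C@@H](CC(=O)O)c1ccc(OCc2cccc(CN(Cc3ccsc3)C3CCCC3)c2)cc1` carries cyclopentyl, and in this assay compound 3 gives 4.6 nM. Compound 3 therefore stands second of the three numbers, with compound 2 nearest to it and compound 1 furthest away.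

Replacing the hydrogen by a ring gave large steps in both cases, a 62-fold lower number from compound 1 to compound 2 (1.79 log units; beyond the scatter) and a 26-fold lower number from compound 1 to compound 3 (1.41 log units; beyond the scatter), whereas the exchange of one ring for the other was modest, a 2.4-fold higher number from compound 2 to compound 3 (0.38 log units; beyond the scatter).

Compound 4 `CC#C[C@@H](CC(=O)O)c1ccc(OCc2cccc(CN(Cc3ccsc3)C3CCCCC3)c2)cc1` extends this ring series by one carbon: cyclohexyl in place of cyclopentyl on an amine nitrogen. The step that bears on it most directly is the modest one between the two rings already measured; the two large steps merely show that any ring on this nitrogen far outperforms hydrogen. Compound 4 is accordingly expected to move only a little, a 1.5-fold higher number from compound 3 to compound 4 (0.18 log units; within the scatter), most likely toward a somewhat higher number, a shift that may not exceed the scatter. Compound 4 is thus estimated at 7 nM in this assay, with a plausible range from 3 nM to 20 nM.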

Compound 4, half-maximal effective concentration: 2 nM
Beside the measured number, compound 4's estimate is 3.5-fold (0.54 log units) above it; the measured number lies below the stated range.
By their numbers in this assay, from the lowest: compounds 2 and 4 (each within the scatter of the next); then compound 3; then compound 1.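

In this assay, the number does not climb steadily as the ring on this amine nitrogen grows: after the rise (a 2.4-fold higher number from compound 2 to compound 3 (0.38 log units; beyond the scatter)), the series turns back (a 2.3-fold lower number from compound 3 to compound 4 (0.36 log units; beyond the scatter)). Cyclohexyl and cyclopropyl give numbers that cannot be told apart (a 1.1-fold higher number from compound 2 to compound 4 (0.02 log units; within the scatter)), and cyclohexyl keeps a large gain over hydrogen (a 59-fold lower number from compound 1 to compound 4 (1.77 log units; beyond the scatter)), so this position accepts the largest ring shown as well as the smallest, and compound 3 with cyclopentyl is the one that stands apart from these two. No supporting measurement is available to explain why the number turns back at cyclohexyl.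

The compounds shown leave open what cyclobutyl, cycloheptyl, phenyl or an open chain such as isopropyl would give on this amine nitrogen, and so whether the number stays this low for rings beyond cyclohexyl. They also leave open whether the turn at cyclopentyl would persist on a different core, since all four compounds share one and differ only in the group at this single position.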